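The source may hold more compounds than are shown below. What is called first, only, known or untested is meant among the compounds shown, and "the series" means these compounds.

In a functional assay on HCT-116 cells (Homo sapiens) for inhibition, read by MTT assay, with a stated time of 2 days, tested at 10 uM (a higher number here means more inhibition of growth at the concentration tested, a lower number less inhibition of growth), compound 1 `CNC(=O)c1cc(Oc2ccc3nc(NC(=O)Nc4ccc(Cl)cc4)sc3c2)ccn1` gives 57.4%, compound 2 `CNC(=O)c1cc(Oc2ccc3nc(NC(=O)c4cc(Cl)cc(Cl)c4)sc3c2)ccn1` gives 13.4% and compound 3 `CNC(=O)c1cc(Oc2ccc3nc(NC(=O)c4cccc(F)n4)sc3c2)ccn1` gives 10.8%. Compound 3 thus holds the lowest of the three numbers; the step of a number 2.6 percentage points lower from compound 2 to compound 3 (within the scatter) is within the scatter, while the step of a number 46.6 percentage points lower from compound 1 to compound 3 (beyond the scatter) is beyond it. Compound 4 `CNC(=O)c1cc(Oc2ccc3nc(NC(=O)Nc4ccc(Br)cc4)sc3c2)ccn1` differs from compound 3 only by (4-bromophenyl)amino in place of 6-fluoropyridin-2-yl on a carbonyl carbon. The step bearing on this is a number 46.6 percentage points lower from compound 1 to compound 3 (beyond the scatter), which this change largely reverses, and the step of a number 44 percentage points lower from compound 1 to compound 2 (beyond the scatter) points the same way. A large rise in this assay is therefore expected for compound 4, roughly a number 44.2 percentage points higher from compound 3 to compound 4 (beyond the scatter), and compound 4 is estimated at 55%, between 35% and 75%.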

Compound 4, percent growth inhibition at one concentration: 12.1%
Estimate against measurement, compound 4: 42.9 percentage points above; the measured number lies below the stated range.
By their numbers in this assay, from the lowest: compounds 3, 4 and 2 (each within the scatter of the next); then compound 1.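

In this assay, the urea-type (4-bromophenyl)amino group does not by itself carry growth inhibition: with bromo in place of chloro on an aromatic carbon, the result is a number 45.3 percentage points lower from compound 1 to compound 4 (beyond the scatter). The group also does not separate from the two aryl groups on the carbonyl carbon, with a number 1.3 percentage points higher from compound 3 to compound 4 (within the scatter) and a number 1.3 percentage points lower from compound 2 to compound 4 (within the scatter). No available evidence accounts for this halogen sensitivity. From the compounds shown here alone, whether fluoro, methyl, methoxy or an amine on that aromatic carbon retains the inhibition seen with chloro stays open.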